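From 4-methylthiophen-2-yl to 4-hydroxyphenyl on the shared core

The source may hold more compounds than are shown below. What is called first, only, known or untested is meant among the compounds shown, and "the series" means these compounds.

In a functional assay on HL-60 cells (Homo sapiens) for inhibition (on this read-out higher numbers stand for weaker inhibition and lower numbers for stronger inhibition), compound 1 (`OC[C@H]1OC(n2cnc3c(-c4ccco4)ncnc32)[C@H](O)[C@@H]1O`), carrying furan-2-yl, gives 2700 nM. Compound 2 (`OC[C@H]1OC(n2cnc3c(-c4ccccn4)ncnc32)[C@H](O)[C@@H]1O`), carrying pyridin-2-yl, gives 5600 nM. Compound 3 (`Cc1csc(-c2ncnc3c2ncn3C2O[C@H](CO)[C@@H](O)[C@H]2O)c1`), carrying 4-methylthiophen-2-yl, gives 5600 nM, level with compound 2, and these two share the highest number of the three.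

Compound 4 (`OC[C@H]1OC(n2cnc3c(-c4ccc(O)cc4)ncnc32)[C@H](O)[C@@H]1O`) has 4-hydroxyphenyl in place of 4-methylthiophen-2-yl on an aromatic carbon of the same six-membered aromatic ring with 2 nitrogen: 4-hydroxyphenyl in place of 4-methylthiophen-2-yl on an aromatic carbon.

All three measured steps are swaps on this aromatic carbon. Replacing furan-2-yl gives a 2.1-fold higher number from compound 1 to compound 2 (0.32 log units; beyond the scatter), a modest move, and likewise a 2.1-fold higher number from compound 1 to compound 3 (0.32 log units; beyond the scatter). Exchanging the two replacement groups gives no change at the digits printed from compound 2 to compound 3 (within the scatter). Within the data shown here, no measured compound has a ring of carbon only at this place, and none has a hydroxy group, so the new group is an extrapolation from three data points. The swaps seen so far are small, and compound 3 already sits at 5600 nM, so no step beyond the scatter is expected in this assay. The estimated step is a 1.1-fold higher number from compound 3 to compound 4 (0.03 log units; within the scatter). For compound 4 the estimated value is 6000 nM, with an expected range of 2000 nM to 20000 nM.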

Compound 4, half-maximal inhibitory concentration: 7600 nM
Beside the measured number, compound 4's estimate is 1.3-fold (0.10 log units) below it; the measured number falls inside the stated range.
By their numbers in this assay, from the lowest: compound 1; then compounds 2, 3 and 4 (each within the scatter of the next).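

A ring of carbon only, in the form of 4-hydroxyphenyl, fits on this aromatic carbon with a result that cannot be told apart from those of the two heteroaromatic groups it is compared with: in this assay the swaps give a 1.4-fold higher number from compound 3 to compound 4 (0.13 log units; within the scatter) and a 1.4-fold higher number from compound 2 to compound 4 (0.13 log units; within the scatter). Against furan-2-yl, the same group gives a 2.8-fold higher number from compound 1 to compound 4 (0.45 log units; beyond the scatter), so compound 1 now stands apart from three compounds carrying different rings, and the hydrogen-bond donor entering with 4-hydroxyphenyl brings no step beyond the scatter from either compound 2 or compound 3. The data at hand offer no measured basis for explaining any of these steps.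

Still open, from the compounds shown here alone, is whether an unsubstituted phenyl, or an amine or a carboxylic acid in place of the hydroxy group of 4-hydroxyphenyl, would move the number in this assay beyond the scatter from compound 4. Also open, going by these compounds, is whether any group on this aromatic carbon, such as a morpholine or a short alkyl chain, can give a lower number than compound 1 does at 2700 nM.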